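Trimming a ring methyl on a succinimide-piperazine amide

The source may report more compounds than this note shows. Statements on the series, on what has been measured and on what is new or still open speak of the compounds shown alone.

Measured compounds:
compound 1 `CCC(C(=O)N1CCN(c2cccc(C(F)(F)F)c2)CC1)N1C(=O)CC(C)C1=O` 75.1 mg/kg
compound 2 `Cc1cccc(N2CCN(C(=O)C(C)N3C(=O)CC(C)C3=O)CC2)c1` 122 mg/kg
compound 3 `CC(C(=O)N1CCN(c2cccc(C(F)(F)F)c2)CC1)N1C(=O)CC(C)(C)C1=O` 114 mg/kg

In a functional assay on the whole organism (strain Swiss) with Mus musculus as the target, in the maximal electroshock model, with a stated time of 0.25 h (a higher number here means that more compound is needed for the effect, a lower number that less compound is needed), compound 3 gives 114 mg/kg, the second highest of the three numbers; compound 2 and compound 1 both lie within the scatter of it, so no order among the three can be claimed. Compound 4 `CC1CC(=O)N(C(C)C(=O)N2CCN(c3cccc(C(F)(F)F)c3)CC2)C1=O` differs from compound 3 by hydrogen in place of methyl on a saturated ring carbon, that is, 3,3-dimethyl-2,5-dioxopyrrolidin-1-yl becomes 3-methyl-2,5-dioxopyrrolidin-1-yl. For the measured compounds named here, no measured pair shows this change alone, but compound 1 and compound 2 already carry the 3-methyl ring and sit within the scatter of compound 3. Compound 4 is therefore expected to show a step from compound 3 of a 1.2-fold lower number from compound 3 to compound 4 (0.08 log units; within the scatter), not beyond the scatter. The estimate for compound 4 in this assay is 95 mg/kg, with a range from 48 mg/kg to 190 mg/kg.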

Compound 4, dose for half-maximal effect: 81.7 mg/kg
Beside the measured number, compound 4's estimate is 1.2-fold (0.07 log units) above it, and the stated range covers the measured number.
By their numbers in this assay, from the lowest: compounds 1, 4, 3 and 2 (each within the scatter of the next).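

Taking one methyl off the saturated ring carbon, two ring bonds from the ring nitrogen, gives the first reading of this change alone in this assay (a 1.4-fold lower number from compound 3 to compound 4 (0.14 log units; within the scatter)), and the step stays within the scatter. Trifluoromethyl in place of methyl on an aromatic carbon (a 1.5-fold lower number from compound 2 to compound 4 (0.17 log units; within the scatter)) and the removal of one methyl from the chain (a 1.1-fold higher number from compound 1 to compound 4 (0.04 log units; within the scatter)) also stay within it. Nothing available bears on why these steps are so small.

From the compounds shown here alone, whether an amine, a carboxylic acid or a longer chain on that ring carbon would move the number beyond the scatter stays open. So does the effect of leaving this ring carbon with hydrogen alone.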